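Extending the Amine Chain of Compound 2

The source may report more compounds than this note shows. Statements on the series, on what has been measured and on what is new or still open speak of the compounds shown alone.

Compound 1 `OC[C@H]1OC(n2cnc3c(S)nccc32)[C@H](O)[C@@H]1O` and compound 2 `CNc1nccc2c1ncn2C1O[C@H](CO)[C@@H](O)[C@H]1O` share one core and differ at a single aromatic carbon, where methylamino stands in place of sulfanyl. In a functional assay on EL4 cells (Mus musculus) for inhibition, tested at 100 uM (on this read-out lower numbers stand for less inhibition and higher numbers for more inhibition at the one concentration tested (going by the name of the read-out)), compound 1 reports only a limit, < 5%. In this assay compound 2 gives 11%, the only number shown among the two. The step of a number at least 6 percentage points higher from compound 1 to compound 2 (that floor lies within the scatter) cannot be sized well because of the limit of < 5% in this assay, at which 1 of the 2 values shown sits. Compound 3 `CCCCCCNc1nccc2c1ncn2C1O[C@H](CO)[C@@H](O)[C@H]1O` has not yet been measured in this assay; it differs from compound 2 by pentyl in place of hydrogen on a saturated chain carbon bound to a nitrogen on an aromatic ring. For the measured compounds named here, no measured step concerns lengthening this chain, and the one step in hand shows nothing beyond the scatter. The estimate for compound 3 therefore rests on the number of compound 2 alone. The step of a number 1 percentage points higher from compound 2 to compound 3 (within the scatter) is expected to stay within the scatter. Compound 3 is thus estimated to give 12%, between 2% and 25%.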

Compound 3, a percentage reported as inhibition, at one concentration (the size of the read-out at that concentration, not a potency): 14%
The estimate for compound 3 lay 2 percentage points below the measured number; the range from low to high includes it.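

For the compounds shown here, the step of a number 3 percentage points higher from compound 2 to compound 3 (within the scatter) is the first measured change on this chain in this assay, and it shows that the hexylamino and methylamino compounds cannot be told apart on this read-out. The earlier compounds shown here had varied only the group on the aromatic carbon, so the length of the chain had not been tested. The comparison with the sulfanyl compound, a number at least 9 percentage points higher from compound 1 to compound 3 (that floor lies within the scatter), also cannot be sized well because its starting value is a limit and not a number: the limit of < 5% in this assay, at which 1 of the 3 values shown sits.

From the compounds shown here alone, whether a chain longer than hexyl, or a chain ending in an amine or a carboxylic acid, would stand apart from compound 2 remains open. Going by these compounds, all three compounds were read at a single concentration, so their potencies also remain unknown.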